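The source may hold more compounds than are shown below. What is called first, only, known or untested is meant among the compounds shown, and "the series" means these compounds.

Measured compounds:
- Compound 1, `CCN(CC)S(=O)(=O)c1ccc(S(=O)(=O)N2CCC[C@@H](C(=O)N[C@H]3CC[C@H](OC)CC3)C2)cc1`: 2000 nM
- Compound 2, `O=C([C@@H]1CCCN(S(=O)(=O)c2ccc(S(=O)(=O)C3CCC3)cc2)C1)N1CCC(F)(F)CC1`: 78 nM
- Compound 3, `O=C([C@@H]1CCCN(S(=O)(=O)c2ccc(S(=O)(=O)C3COC3)cc2)C1)N1CCC(F)(F)CC1`: 361 nM

All three were tested in a functional assay on BXPC-3 cells (Homo sapiens) for inhibition, read by MTT assay, with a stated time of 7 days; on this read-out higher numbers stand for weaker inhibition and lower numbers for stronger inhibition. On this read-out compound 1 stands at the top of the three numbers, that is, it is the weakest inhibitor of the set: compound 3 sits a good deal lower, and compound 2 lower still.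

Compound 4, `CCN(CC)S(=O)(=O)c1ccc(S(=O)(=O)N2CCC[C@@H](C(=O)NC3COC3)C2)cc1`, has not been measured. It differs from compound 1 in one place: oxetan-3-yl in place of 4-methoxycyclohexyl on an amide-type nitrogen. Among the measured compounds shown here, the only measured step with a related flavour is a 4.6-fold higher number from compound 2 to compound 3 (0.67 log units; beyond the scatter), where the oxetane also replaced a carbon-only ring, although there it sat on a sulfonyl sulfur rather than on the amide nitrogen, and the ring it replaced was smaller than the 4-methoxycyclohexyl ring leaving here. That step therefore bears on the present change only loosely, but it points in one direction: swapping a carbon ring for an oxetane raised the number. For compound 4 a modest rise in this assay is expected, as in a 2.5-fold higher number from compound 1 to compound 4 (0.40 log units; beyond the scatter), with wide uncertainty. The estimate for compound 4 is 5000 nM, expected to fall between 1500 nM and 16000 nM.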

Compound 4, half-maximal inhibitory concentration: 13800 nM
For compound 4 the middle estimate is 2.8-fold (0.44 log units) below the measured one; measured number inside the range.
By their numbers in this assay, from the lowest: compound 2; then compound 3; then compound 1; then compound 4.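

In this assay, the group on the amide-type nitrogen clearly affects the result, with a 6.9-fold higher number from compound 1 to compound 4 (0.84 log units; beyond the scatter) when oxetan-3-yl replaces 4-methoxycyclohexyl. The earlier oxetane step was on a sulfonyl sulfur, so this is the first sign that a swap at this nitrogen also raises the number, and both oxetane swaps shown now point the same way. No measurement shown explains this rise.

This change alters ring size, ring atoms and the methoxy group all at once, so the compounds shown cannot tell which of these differences matters. A plain cyclohexyl, a tetrahydropyran-4-yl or an open 2-methoxyethyl chain on the same nitrogen could help separate these differences.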